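Ring-nitrogen substituent and metabolic stability of the shared core

This account rests on a few compounds, and the source may have more. Where it says the series, first, only, none or still open, it means among the compounds named here.

Measured so far:
compound 1 `O=C(O)c1cc(-c2cccc(COc3ccc4c(c3)CN(Cc3ccc(C(F)(F)F)cc3)C4=O)c2)ccc1Cl` — 100%
compound 2 `O=C(O)c1cc(-c2cccc(COc3ccc4c(c3)CN(C3CCCCC3)C4=O)c2)ccc1Cl` — 1%
compound 3 `CCCN1Cc2cc(OCc3cccc(-c4ccc(Cl)c(C(=O)O)c4)c3)ccc2C1=O` — 96%

In an ADME assay on microsomes from liver (Rattus norvegicus) for metabolic stability, with a stated time of 60 min (a higher number here means that more of the compound is left, a lower number that less of the compound is left), compound 2 stands lowest of the three. The nearest number is that of compound 3, with a number 95 percentage points higher from compound 2 to compound 3 (beyond the scatter); the furthest is compound 1, the step of a number 99 percentage points lower from compound 1 to compound 2 (beyond the scatter) running the other way. Compound 4 `O=C(O)c1cc(-c2cccc(COc3ccc4c(c3)CN(CC3CC3)C4=O)c2)ccc1Cl` is the next analogue: cyclopropylmethyl in place of cyclohexyl on an amide-type nitrogen in a ring. Among the compounds with values here, two steps bear on it. Replacing cyclohexyl on the ring nitrogen by propyl gave a number 95 percentage points higher from compound 2 to compound 3 (beyond the scatter), and the change from compound 1 to compound 2, a number 99 percentage points lower from compound 1 to compound 2 (beyond the scatter), points the same way. A large rise beyond the scatter is therefore expected for compound 4, estimated as a number 74 percentage points higher from compound 2 to compound 4 (beyond the scatter). Compound 4 is expected to give about 75%, within 35% to 100%.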

Compound 4, percent of the compound remaining: 73%
The estimate for compound 4 lay 2 percentage points above the measured number; the range from low to high includes it.
By their numbers in this assay, from the lowest: compound 2; then compound 4; then compounds 3 and 1 (each within the scatter of the next).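

In this assay a ring of carbon only on the amide-type nitrogen is not enough for a low number: cyclopropylmethyl gives a number 72 percentage points higher from compound 2 to compound 4 (beyond the scatter) and so sets compound 4 well apart from compound 2. The small ring on the saturated chain carbon still carries a cost, with a number 23 percentage points lower from compound 3 to compound 4 (beyond the scatter) against ethyl and a number 27 percentage points lower from compound 1 to compound 4 (beyond the scatter) against 4-(trifluoromethyl)phenyl. Nothing available accounts for these differences.

Going by these compounds, it remains open whether the low number of compound 2 follows from a ring bound directly to the nitrogen or from cyclohexyl itself. Cyclopentyl and cyclohexylmethyl on the same nitrogen would separate these readings.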